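The compounds below may be only part of what the source reports. "The series", "measured", "known", "first", "only" and "open" are said of these compounds alone.

Three compounds built on one shared core were tested in a functional assay on PC-3 cells (Homo sapiens) for cytotoxicity, read by MTT assay; on this read-out higher numbers stand for weaker inhibition and lower numbers for stronger inhibition. Compound 1 `COc1cccc(/C=C/C(=O)c2sc(Nc3ccccc3)nc2C)c1` gives only a limit of the assay in this assay, > 25000 nM. Compound 2 `Cc1nc(Nc2ccccc2)sc1C(=O)/C=C/c1ccc(Cl)cc1` likewise gives only a limit in this assay, > 25000 nM. Compound 3 `Cc1nc(Nc2ccccc2)sc1C(=O)/C=C/c1ccccc1` also gives only a limit, > 25000 nM. Compound 2 thus stands with no number, only a limit, as the limit of > 25000 nM in this assay, at which 3 of the 3 values shown sit, makes plain. The steps among the three, a step that the two limits leave unreadable from compound 1 to compound 2, a step that the two limits leave unreadable from compound 1 to compound 3 and a step that the two limits leave unreadable from compound 2 to compound 3, all have sizes that cannot be read. The untested compound 4 `Cc1cccc(Nc2nc(C)c(C(=O)/C=C/c3ccc(Cl)cc3)s2)c1` differs from compound 2 by methyl in place of hydrogen on an aromatic carbon. For the measured compounds named here, no measured step touches this change: the measured steps concern the aryl on the double-bonded chain carbon, not the anilino group, and none of them yields a readable size. The step that the limit leaves unreadable from compound 2 to compound 4 is therefore expected to be one that cannot be read either, with compound 4 staying at the limit. The estimate for compound 4 is 35000 nM, spanning 12000 nM to 100000 nM.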

Compound 4, half-maximal inhibitory concentration: > 25000 nM
Compound 4: only a limit was reported; the forecaster's own chance of this, stated with the estimate: 80%; the middle value is on the limit's open side.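

No new step can be read: compound 2 and compound 4 both give only a limit, so the change from phenyl to 3-methylphenyl has no readable size. The compounds shown leave open how far each lies beyond that limit in this assay, and which change to the shared core would give a measurable value.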